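This account rests on a few compounds, and the source may have more. Where it says the series, first, only, none or still open, it means among the compounds named here.

Measured so far:
compound 1, `COc1ccccc1/C=C/C=N/N1C(=S)NC2C1N(C)C(=O)N2c1ccccc1`, in a functional assay on A549 cells (Homo sapiens) for inhibition, read by MTT assay, with a stated time of 72 h; a higher number here means a weaker inhibitor, a lower number a stronger inhibitor: > 100000 nM
compound 2, `CCN1C(=O)N(CC)C2C1NC(=S)N2/N=C/C=C/c1ccccc1[N+](=O)[O-]`, in this assay: > 100000 nM

Both values shown are limits of the assay and not numbers. Compound 2 stands only at a limit in this assay. Compound 1 likewise gives only a limit. Both measured compounds therefore sit at the limit of > 100000 nM in this assay, at which 2 of the 2 values shown sit, and nothing in the numbers separates them.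

Compound 3, `CCN1C(=O)N(CC)C2C1NC(=S)N2/N=C/C=C/c1ccc(OC)cc1`, differs from compound 2 by 4-methoxyphenyl in place of 2-nitrophenyl on a double-bonded chain carbon bound to a double-bonded chain carbon. Among the compounds with values here, no step between two measured compounds exists, so nothing measured tells how an exchange at this place moves this assay. With compound 2 giving only a limit, no step beyond the scatter is expected in either direction, and a limit is the likelier outcome for compound 3 as well. The step expected is a number no higher from compound 2 to compound 3 (the limit leaves the size open), in short none. Compound 3 is estimated at 100000 nM, with a range from 30000 nM to 300000 nM.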

Compound 3, half-maximal inhibitory concentration: 17200 nM
Estimate against measurement, compound 3: 5.8-fold (0.76 log units) above; the whole stated range lies above it.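

In this assay, 4-methoxyphenyl in place of 2-nitrophenyl on a double-bonded chain carbon bound to a double-bonded chain carbon gives an at least 5.8-fold lower number from compound 2 to compound 3 (0.76 log units; beyond the scatter). This place on the chain can therefore move the read-out beyond the scatter, which compound 1 and compound 2 alone could not show. Compound 1 and compound 2 stand at a limit and not at a number, so the full size of the step stays open: the limit of > 100000 nM in this assay, at which 2 of the 3 values shown sit.

Within the data shown here, compound 1 also carries a methoxy group but differs from compound 3 in more than one place, so no step between them can be read, and the role of the methoxy group compared with the absence of the nitro group remains unresolved. From the compounds shown here alone, how an unsubstituted phenyl, or a phenyl bearing an amine or a carboxylic acid, would behave at this place also remains open.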